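Chain-extended propargylamines in the MAO-A inhibition series

The source may hold more compounds than are shown below. What is called first, only, known or untested is meant among the compounds shown, and "the series" means these compounds.

The series pairs two cores. Compound 1 `C#CCN(C)CCCCCOc1ccc2c(c1)CCCC2=O` and compound 2 `C#CCN(C)CCCCCCOc1ccc2c(c1)CCCC2=O` share one core; compound 3 `C#CCN(C)CCCCCOc1ccc2c(c1)OCCC2=O` and the still unmeasured compound 4 `C#CCN(C)CCCCCCOc1ccc2c(c1)OCCC2=O` share the other. How the core of compound 3 differs from the core of compound 1 is not broken down here.

In an ADME assay on BTI cells for inhibition of Amine oxidase [flavin-containing] A (Homo sapiens), read by fluorescence and Amplex Red, with a stated time of 15 min, tested at 100 uM (a higher number here means more inhibition at the concentration tested (going by the name of the read-out), a lower number less inhibition), compound 1 gives 26.1%. Compound 2 gives 25% in this assay. Within the data shown here, the single change between them is (methyl(propargyl)amino)methyl in place of methyl(propargyl)amino on a saturated chain carbon, five bonds along the chain from an oxygen on an aromatic ring; the step it made, a number 1.1 percentage points lower from compound 1 to compound 2 (within the scatter), lies within the scatter, so the two values are read as the same.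

Compound 3 gives 6.04% in this assay, the lowest of the three numbers, and its gaps to compound 1 and to compound 2 are both beyond the scatter.

Compound 4 carries, on the core of compound 3, the same change: (methyl(propargyl)amino)methyl in place of methyl(propargyl)amino on a saturated chain carbon, five bonds along the chain from an oxygen on an aromatic ring. The place line reads identically for both pairs, so the change is the same, not merely the same kind. Among the measured compounds shown here, with only one measured instance of it, the expectation for compound 4 rests on that one pair: the step from compound 3 to compound 4 in this assay is expected to be small, a number 0 percentage points lower from compound 3 to compound 4 (within the scatter), because the earlier instance gave a number 1.1 percentage points lower from compound 1 to compound 2 (within the scatter). Compound 4 is therefore estimated at 6% in this assay, expected to lie between -4% and 16%.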

Compound 4, a percentage reported as inhibition, at one concentration (the size of the read-out at that concentration, not a potency): 34.1%
Compound 4: middle estimate off by 28.1 percentage points, on the low side, and the stated range ends below it.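

Working notes on carrying the chain extension between cores. On the core of compound 3, (methyl(propargyl)amino)methyl in place of methyl(propargyl)amino goes with a number 28.1 percentage points higher from compound 3 to compound 4 (beyond the scatter) in this assay, so the near-zero step on the core of compound 1 gives no reliable guide to the step on the other core. The change therefore does not transfer as a fixed increment between these two cores: the same change on two cores in this assay, a number 1.1 percentage points lower (within the scatter) from compound 1 to compound 2 and a number 28.1 percentage points higher (beyond the scatter) from compound 3 to compound 4, 29.2 percentage points apart, beyond the scatter of two such steps This shows that the outcome of this one change depends on the core it sits on, but it rests on just two pairs of compounds, each read at a single concentration, so it gives no potency and no general rule for other cores, nor does it say which feature of the cores accounts for the difference.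

The compounds shown leave open whether a longer chain, such as one ending in 2-(methyl(propargyl)amino)ethyl, would continue the rise on the core of compound 3 or bring a step like the one on the core of compound 1. They also leave open whether the same core dependence would hold for a tertiary amine carrying an ethyl group in place of the propargyl group.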